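Swapping 4-Methoxyphenyl for 2,4-Dichlorophenyl on the Core

The compounds below may be only part of what the source reports. "The series", "measured", "known", "first", "only" and "open" are said of these compounds alone.

Of the compounds shown here, three sharing one core have been measured in a functional assay on MCF7 cells (Homo sapiens) for antiproliferative activity, read by MTT assay, with a stated time of 72 h; a lower number here means a stronger inhibitor, a higher number a weaker inhibitor. Compound 1 `COc1cc(-n2cnc3ccc(-c4ccc([N+](=O)[O-])cc4)cc32)cc(OC)c1OC` gives 740 nM. Compound 2 `COc1cc(-n2cnc3ccc(-c4cccc(F)c4)cc32)cc(OC)c1OC` gives 2350 nM. Compound 3 `COc1ccc(-c2ccc3ncn(-c4cc(OC)c(OC)c(OC)c4)c3c2)cc1` gives 210 nM, the lowest number of the three; its nearest neighbour is compound 1, and compound 2 lies furthest away. The two steps that reach compound 3 are a 3.5-fold lower number from compound 1 to compound 3 (0.55 log units; beyond the scatter) and an 11-fold lower number from compound 2 to compound 3 (1.05 log units; beyond the scatter).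

Compound 4 `COc1cc(-n2cnc3ccc(-c4ccc(Cl)cc4Cl)cc32)cc(OC)c1OC` differs from compound 3 in one place: 2,4-dichlorophenyl in place of 4-methoxyphenyl on an aromatic carbon. Among the compounds with values here, no compound in this set carries a 2,4-dichlorophenyl group, so the step can only be judged from the neighbours. The step of an 11-fold lower number from compound 2 to compound 3 (1.05 log units; beyond the scatter) shows that a halogen-bearing phenyl gave a far higher number than 4-methoxyphenyl, and a 3.5-fold lower number from compound 1 to compound 3 (0.55 log units; beyond the scatter) shows that 4-methoxyphenyl also beat 4-nitrophenyl. Removing the methoxy group is therefore expected to cost potency, and the estimated step is a 5.7-fold higher number from compound 3 to compound 4 (0.76 log units; beyond the scatter). Compound 4 is estimated at 1200 nM, within a range of 400 nM to 4000 nM.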

Compound 4, half-maximal inhibitory concentration: 5420 nM
Estimate against measurement, compound 4: 4.5-fold (0.65 log units) below, and the stated range ends below it.
By their numbers in this assay, from the lowest: compound 3; then compound 1; then compound 2; then compound 4.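

In this assay, compound 4 is the weakest inhibitor of the four, with 2,4-dichlorophenyl giving a 26-fold higher number from compound 3 to compound 4 (1.41 log units; beyond the scatter), a 2.3-fold higher number from compound 2 to compound 4 (0.36 log units; beyond the scatter) and a 7.3-fold higher number from compound 1 to compound 4 (0.86 log units; beyond the scatter). This extends the range of numbers reached by changing the group on this aromatic carbon beyond the one set by the first three compounds, and the steps show that a change here can cost far more than compound 2 had suggested. Among the four compounds, the two halogen-bearing phenyl groups, in compound 2 and compound 4, give the two highest numbers, and no compound shown goes against this.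

No measurement available here accounts for the size of these steps. The compounds shown leave open whether the number depends on the kind, count or placement of halogen, and how a phenyl group carrying an amine or a carboxylic acid would stand in this place.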